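Swapping the Ring Substituent in an Acid Ceramidase Inhibitor

This account rests on a few compounds, and the source may have more. Where it says the series, first, only, none or still open, it means among the compounds named here.

Compound 1 `COc1ccc(CCCCNC(=O)n2c(=O)oc3ccccc32)cc1` carries a four-carbon chain from the amide-type nitrogen to a ring bearing a methoxy group. In an assay on HEK293 cells for inhibition of acid ceramidase (Homo sapiens), with a stated time of 10 min (on this read-out lower numbers stand for stronger inhibition and higher numbers for weaker inhibition), compound 1 gives 63 nM, the highest of the three numbers gathered here. Compound 2 `O=C(NCCCCCc1ccccc1)n1c(=O)oc2ccccc21` gives 54 nM and compound 3 `O=C(NCCCCc1cccs1)n1c(=O)oc2ccccc21` gives 37 nM; the steps of a 1.2-fold lower number from compound 1 to compound 2 (0.07 log units; within the scatter) and a 1.7-fold lower number from compound 1 to compound 3 (0.23 log units; within the scatter) show that exchanging the whole ring at the chain end leaves the read-out essentially where it was. Compound 4 `O=C(NCCCCc1ccc([N+](=O)[O-])cc1)n1c(=O)oc2ccccc21` differs from compound 1 by nitro in place of methoxy on an aromatic carbon. Among the compounds with values here, no measured step tests this exact exchange, yet the two ring swaps bear on the same chain end and both stayed within the scatter. For compound 4 an unchanged outcome is therefore expected, a step of a 1.1-fold lower number from compound 1 to compound 4 (0.06 log units; within the scatter), giving an estimated 55 nM with a range from 20 nM to 150 nM.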

Compound 4, half-maximal inhibitory concentration: 312 nM
Compound 4: middle estimate off by 5.7-fold (0.75 log units), on the low side; measured number outside the range, above it.
By their numbers in this assay, from the lowest: compounds 3, 2 and 1 (each within the scatter of the next); then compound 4.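

The earlier swaps exchanged the whole ring at the chain end and stayed within the scatter, so they did not test a group on that ring. Within the data shown here, with a 5.0-fold higher number from compound 1 to compound 4 (0.69 log units; beyond the scatter) in this assay, nitro in place of methoxy, para to a large group, is the first change here to go beyond the scatter, so the read-out does respond to the group at this position. Nothing measured here explains the shift.

Going by these compounds, whether this shift is particular to nitro stays open, since an amine or a carboxylic acid at the same position would show how other groups fare. On these data alone, whether nitro has the same effect on a longer chain also remains open.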